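Ring Substituents on the Sulfonamide and Antiproliferative Potency

A few compounds are considered here, and "the series" means these few. Any claim that something is new, unique, unknown or untested is made for them only; others in the source may bear on it.

Measured so far:
Compound 1, `O=C(/C=C/c1cccc(NS(=O)(=O)c2ccccc2Cl)c1)c1nc2ccccc2[nH]1`: 4280 nM
Compound 2, `O=C(/C=C/c1cccc(NS(=O)(=O)c2ccc(Cl)cc2)c1)c1nc2ccccc2[nH]1`: 3820 nM
Compound 3, `O=C(/C=C/c1cccc(NS(=O)(=O)c2cc(Cl)cc(Cl)c2)c1)c1nc2ccccc2[nH]1`: 20000 nM

Of the compounds shown here, three sharing the same core have been tested in a functional assay on MCF7 cells (Homo sapiens) for antiproliferative activity, read by MTT assay, with a stated time of 48 h; a higher number here means a weaker inhibitor, a lower number a stronger inhibitor. Compound 1 carries a 2-chlorophenyl on the sulfonyl sulfur, compound 2 a 4-chlorophenyl, and compound 3 a 3,5-dichlorophenyl. In this assay compound 3 gives the highest number of the three: the step of a 4.7-fold higher number from compound 1 to compound 3 (0.67 log units; beyond the scatter) and the step of a 5.2-fold higher number from compound 2 to compound 3 (0.72 log units; beyond the scatter) are both beyond the scatter, whereas the step of a 1.1-fold lower number from compound 1 to compound 2 (0.05 log units; within the scatter) is within it. Compound 3 is therefore the weakest inhibitor of the three.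

Compound 4, `Cc1ccc(S(=O)(=O)Nc2cccc(/C=C/C(=O)c3nc4ccccc4[nH]3)c2)cc1C`, has not yet been measured in this assay. It differs from compound 3 in one place: 3,4-dimethylphenyl in place of 3,5-dichlorophenyl on a sulfonyl sulfur. Among the compounds with values here, no measured step involves a dimethylphenyl, so the only bearing steps are those that replace the 3,5-dichlorophenyl of compound 3 by a singly substituted ring, each a modest move to a lower number. From the compounds shown here alone, on that basis compound 4 is expected to give a lower number than compound 3, estimated as the step of a 3.3-fold lower number from compound 3 to compound 4 (0.52 log units; beyond the scatter), though whether a second methyl behaves like a second chlorine is unknown. The estimate for compound 4 is 6000 nM, with a range from 2000 nM to 18000 nM.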

Compound 4, half-maximal inhibitory concentration: 5860 nM
Beside the measured number, compound 4's estimate is 1.0-fold (0.01 log units) above it, within the range that was stated.
By their numbers in this assay, from the lowest: compounds 2, 1 and 4 (each within the scatter of the next); then compound 3.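

In this assay, a ring carrying two substituents on the sulfonyl sulfur does not by itself give a high number: replacing the 3,5-dichlorophenyl with 3,4-dimethylphenyl gives a 3.4-fold lower number from compound 3 to compound 4 (0.53 log units; beyond the scatter). The result also places the disubstituted ring of compound 4 level with the singly chlorinated rings, with a 1.5-fold higher number from compound 2 to compound 4 (0.19 log units; within the scatter) and a 1.4-fold higher number from compound 1 to compound 4 (0.14 log units; within the scatter), both within the scatter, so among these four compounds only the 3,5-dichlorophenyl stands apart. No available evidence bears on why these rings differ.

Because compound 4 changes both the atoms on the ring and their arrangement relative to compound 3, the compounds shown cannot say which of the two matters; a 3,4-dichlorophenyl or a 3,5-dimethylphenyl on the sulfonyl sulfur would separate them. It also remains open how this position would respond to a ring bearing a methoxy group, an amine or a carboxylic acid, since all the rings shown carry only chlorine atoms or methyl groups.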